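The compounds below may be only part of what the source reports. "The series", "measured", "known", "first", "only" and "open" are said of these compounds alone.

Measured in an ADME assay on L02 cells (Homo sapiens) for cytotoxicity, read by MTT assay, with a stated time of 24 h; on this read-out lower numbers stand for stronger inhibition and higher numbers for weaker inhibition:
- Compound 1 `COc1cc(/C=C2\CN(C)C/C(=C\c3ccc(Cl)cc3)C2=O)cc(OC)c1` gives 18900 nM
- Compound 2 `COc1cc(/C=C2\CN(C)C/C(=C\c3ccc(F)cc3)C2=O)cc(OC)c1OC` gives 10700 nM
- Compound 3 `COc1cc(/C=C2\CN(C)C/C(=C\c3ccc(Cl)cc3)C2=O)cc(OC)c1OC` gives 14000 nM

Compound 3 sits within the scatter of both compounds joined to it by a single change. The next compound to be tested is compound 4 `COc1cc(/C=C2\CN(C)C/C(=C\c3ccc(Cl)c(Cl)c3)C2=O)cc(OC)c1OC`, which differs from compound 3 as follows: chloro in place of hydrogen on an aromatic carbon. This is chloro in place of hydrogen on an aromatic carbon, ortho to the existing chloro group and meta to a large group, so 4-chlorophenyl becomes 3,4-dichlorophenyl.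

For the measured compounds named here, no measured step makes this exact change, so the evidence is indirect. The closest is the halogen exchange on the same aromatic ring, a 1.3-fold higher number from compound 2 to compound 3 (0.12 log units; within the scatter). The other is the addition of a methoxy group in place of hydrogen, a 1.4-fold lower number from compound 1 to compound 3 (0.13 log units; within the scatter). Both are small, and neither gives a direction that can be carried over to a new chloro group. With only these steps to go on, no shift beyond the scatter is expected in this assay.

The expected step is a 1.2-fold lower number from compound 3 to compound 4 (0.07 log units; within the scatter). For compound 4 the estimated value is 12000 nM, with an expected range of 6000 nM to 24000 nM.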

Compound 4, half-maximal inhibitory concentration: 18400 nM
Compound 4: middle estimate off by 1.5-fold (0.19 log units), on the low side; the measured number falls inside the stated range.
By their numbers in this assay, from the lowest: compounds 2, 3, 4 and 1 (each within the scatter of the next).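

Working notes: in this assay, adding a second chloro to the ring, so that 4-chlorophenyl becomes 3,4-dichlorophenyl, gives a 1.3-fold higher number from compound 3 to compound 4 (0.12 log units; within the scatter) and shows that this position, ortho to the existing chloro group, accepts a further chloro with no shift beyond the scatter. The wider replacement of 4-fluorophenyl by 3,4-dichlorophenyl gives a 1.7-fold higher number from compound 2 to compound 4 (0.24 log units; within the scatter) and also stays within the scatter, so the halogen changes on this ring shown so far do not separate the compounds in this assay. No measurement accompanying these numbers speaks to the origin of either step.

All the compounds shown carry at least one halogen on this ring, so how a carboxylic acid, an amine or a longer alkoxy chain at the same position would read in this assay remains open. Also open is whether any single change on this ring can move the number beyond the scatter, since every step shown so far stays within it.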